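A few compounds are considered here, and "the series" means these few. Any claim that something is new, unique, unknown or untested is made for them only; others in the source may bear on it.

Measured so far in a functional assay on Bel-7402 cells (Homo sapiens) for antiproliferative activity, read by MTT assay, with a stated time of 72 h; on this read-out higher numbers stand for weaker inhibition and lower numbers for stronger inhibition:
- compound 1 `C=C1C(=O)O[C@H]2[C@H]1CC/C(COC(=O)Cn1cc(F)c(=O)[nH]c1=O)=C\CC[C@@]1(C)O[C@@H]21`: > 20000 nM
- compound 2 `C=C1C(=O)O[C@H]2[C@H]1CC/C(COC(=O)Cn1cc(F)c(=O)n(Cc3ccccc3)c1=O)=C\CC[C@@]1(C)O[C@@H]21`: 3980 nM
- compound 3 `C=C1C(=O)O[C@H]2[C@H]1CC/C(COC(=O)Cn1cc(F)c(=O)n(Cc3ccc(C(F)(F)F)cc3)c1=O)=C\CC[C@@]1(C)O[C@@H]21`: 2250 nM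

Compound 1 is held only by a limit of the assay, > 20000 nM. That leaves two true numbers in the series. Compound 3 stands at 2250 nM, within the scatter of compound 2.

Compound 4 `C=C1C(=O)O[C@H]2[C@H]1CC/C(COC(=O)Cn1cc(F)c(=O)n(Cc3ccc(F)cc3F)c1=O)=C\CC[C@@]1(C)O[C@@H]21` differs from compound 3 as follows: 2,4-difluorophenyl in place of 4-(trifluoromethyl)phenyl on a saturated chain carbon bound to an aromatic nitrogen. In words, 2,4-difluorophenyl replaces 4-(trifluoromethyl)phenyl on a saturated chain carbon bound to an aromatic nitrogen.

The large steps are the ones that fill the aromatic nitrogen: an at least 5.0-fold lower number from compound 1 to compound 2 (0.70 log units; beyond the scatter) with benzyl, and an at least 8.8-fold lower number from compound 1 to compound 3 (0.94 log units; beyond the scatter) with 4-(trifluoromethyl)benzyl. Compound 4 keeps that nitrogen filled, with 2,4-difluorobenzyl, so these steps do not apply to the change at hand. Among the measured compounds shown here, the closest precedent is a change on the aromatic ring alone, a 1.8-fold lower number from compound 2 to compound 3 (0.25 log units; within the scatter), which stays within the scatter. No step beyond the scatter is therefore expected in this assay. The expected move is a 1.3-fold higher number from compound 3 to compound 4 (0.12 log units; within the scatter).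

For compound 4 the estimated value is 3000 nM, with an expected range from 1300 nM to 7000 nM.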

Compound 4, half-maximal inhibitory concentration: 3670 nM
The estimate for compound 4 lay 1.2-fold (0.09 log units) below the measured number; the range from low to high includes it.
By their numbers in this assay, from the lowest: compounds 3, 4 and 2 (each within the scatter of the next). At a limit, above all of these: compound 1.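

In this assay, the swap at this place, on a saturated chain carbon bound to an aromatic nitrogen, gives a 1.6-fold higher number from compound 3 to compound 4 (0.21 log units; within the scatter) and a 1.1-fold lower number from compound 2 to compound 4 (0.04 log units; within the scatter). With a third ring added, phenyl, 4-(trifluoromethyl)phenyl and 2,4-difluorophenyl still cannot be told apart in this read-out, and a substituent pattern carrying fluorine on the ring directly shows no separation from the unsubstituted phenyl. Filling the aromatic nitrogen with 2,4-difluorobenzyl also gives an at least 5.4-fold lower number from compound 1 to compound 4 (0.73 log units; beyond the scatter), the third such step from the same starting point, but its size is only a bound, set by: the limit of > 20000 nM in this assay, at which 1 of the 4 values shown sits.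

Going by these compounds, whether the aromatic ring itself is needed remains open, as a plain methyl or a longer alkyl chain on that nitrogen would show. Also open, on these data alone, is how a benzyl ring carrying an amine or a carboxylic acid would read in this assay.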